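Fluorine Position on the Aryl Piperazine of Compound 1

This account rests on a few compounds, and the source may have more. Where it says the series, first, only, none or still open, it means among the compounds named here.

Compound 1 `O=C(CN1CCN(c2cccc(F)c2)CC1)Nc1nc2c(s1)CCCC2` was tested in an assay on isolated protein for inhibition of long-chain fatty acid transport protein 1 (Homo sapiens), read by scintillation counting, with a stated time of 20 min (a higher number here means a weaker inhibitor, a lower number a stronger inhibitor), where compound 1 gives only a limit of the assay, > 1000 nM, and not a number. Compound 2 `O=C(CN1CCN(c2ccc(F)cc2)CC1)Nc1nc2ccccc2s1` carries a different core together with the aryl group that compound 3 will have; in this assay compound 2 gives 490 nM. Compound 1 and compound 2 differ in two places, so no single step can be read between them. Compound 3 `O=C(CN1CCN(c2ccc(F)cc2)CC1)Nc1nc2c(s1)CCCC2` keeps the core of compound 1 and alters only the aryl group: 4-fluorophenyl in place of 3-fluorophenyl on an amine nitrogen in a ring. Going by the values given here, no measured step covers this change on its own. A step of moderate size toward stronger inhibition is nevertheless expected, a step that the limit leaves unreadable from compound 1 to compound 3, guided by what compound 2 shows at 490 nM. Compound 3 is therefore estimated at 1500 nM, within a range from 400 nM to 6000 nM.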

Compound 3, half-maximal inhibitory concentration: 77 nM
The estimate for compound 3 lay 19-fold (1.29 log units) above the measured number; measured number below the stated range.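

With the core of compound 1 held fixed, 4-fluorophenyl in place of 3-fluorophenyl on an amine nitrogen in a ring gives, in this assay, an at least 12-fold lower number from compound 1 to compound 3 (1.11 log units; beyond the scatter). Going by these compounds alone, the two compounds have the same atoms, joined differently, so the place of the single fluorine on this aryl group is enough on its own to carry a large step, which the earlier compounds could not show. Compound 1 gives a limit of the assay and not a number, so the step is a bound and its full size stays unknown: the limit of > 1000 nM in this assay, at which 1 of the 3 values shown sits.

Going by these compounds, whether 4-chlorophenyl, 4-methoxyphenyl or plain phenyl on the same nitrogen would match compound 3 remains open. Also open, on these data alone, is whether 3-fluorophenyl would give a similar step on the core of compound 2, which with 4-fluorophenyl gives 490 nM.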